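Swapping Methyl for 4-Fluorophenyl: What Should Compound 3 Do?

A few compounds are considered here, and "the series" means these few. Any claim that something is new, unique, unknown or untested is made for them only; others in the source may bear on it.

Of the compounds shown here, two with a shared core have been measured so far. Compound 1 `O=C1Nc2ccccc2/C1=N/NC(=S)Nc1cccnc1` reads > 50000 nM in a functional assay on KB 3-1 cells (Homo sapiens) for cytotoxicity, read by MTT assay, with a stated time of 72 h (a higher number here means a weaker inhibitor, a lower number a stronger inhibitor), and this is a limit of the assay, not a number. Among the compounds with values here, compound 2 `CNC(=S)N/N=C1\C(=O)Nc2ccccc21` gives 35300 nM, the only exact number available, so there is little to rank it against.

Compound 3 `O=C1Nc2ccccc2/C1=N/NC(=S)Nc1ccc(F)cc1` keeps that core and changes one group: 4-fluorophenyl in place of methyl on an amide-type nitrogen. In short, 4-fluorophenyl takes the place of methyl on an amide-type nitrogen.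

Within the data shown here, only one measured step bears on this change, an at least 1.4-fold lower number from compound 1 to compound 2 (0.15 log units; that floor lies within the scatter). It exchanges pyridin-3-yl and methyl on the same kind of nitrogen, but it rests on a limit, as the limit of > 50000 nM in this assay, at which 1 of the 2 values shown sits, shows. Among the measured compounds shown here, with that step as the only guide, no clear change beyond the scatter is expected in this assay, and the range must stay wide. The estimate means an expected 1.4-fold lower number from compound 2 to compound 3 (0.15 log units; within the scatter). For compound 3 the expected value is 25000 nM, with an estimated range of 9000 nM to 50000 nM.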

Compound 3, half-maximal inhibitory concentration: 14200 nM
Compound 3: the middle estimate sits 1.8-fold (0.25 log units) above what was measured, within the range that was stated.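

On the amide-type nitrogen whose other neighbour is the thiocarbonyl carbon, the change in this assay now gives a step that clears the scatter: 4-fluorophenyl in place of methyl brings a 2.5-fold lower number from compound 2 to compound 3 (0.40 log units; beyond the scatter) and so shows that this position can respond to the group placed on it, which the earlier step within the scatter could not show. With 4-fluorophenyl in place of pyridin-3-yl there is also an at least 3.5-fold lower number from compound 1 to compound 3 (0.54 log units; beyond the scatter) and, as both steps from compound 3 lie beyond the scatter, compound 3 is the strongest of the three compounds shown. The value of compound 1 is a limit of the assay, so the second step gives only a floor for its size: the limit of > 50000 nM in this assay, at which 1 of the 3 values shown sits.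

Going by these compounds, whether the lower number comes from the six-membered aromatic ring or from its fluorine stays open, and a plain phenyl on this nitrogen would help to separate the two. How a longer chain such as propyl, or a ring carrying an amine or a carboxylic acid, would behave at this position also remains an open question.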